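The source may hold more compounds than are shown below. What is called first, only, known or untested is meant among the compounds shown, and "the series" means these compounds.

Working notes on the series. Compound 1 `O=[N+]([O-])c1cc(CSc2nnc(C3CCCCC3)n2Cc2ccccc2)cc(C(F)(F)F)c1`, compound 2 `Cn1c(SCc2ccccc2)nnc1-c1cc([N+](=O)[O-])cc([N+](=O)[O-])c1`, compound 3 `COc1ccc(CSc2nnc(-c3cc([N+](=O)[O-])cc([N+](=O)[O-])c3)n2C)cc1` and the unmeasured compound 4 `Cn1c(SCc2ccc(Cl)cc2)nnc1-c1cc([N+](=O)[O-])cc([N+](=O)[O-])c1` are the four members in view. In an ADME assay on HepG2 cells (Homo sapiens) for cytotoxicity, with a stated time of 48 h (on this read-out higher numbers stand for weaker inhibition and lower numbers for stronger inhibition), compound 1 gives > 30000 nM, a limit of the assay. Compound 2 gives > 30000 nM, also a limit. Compound 3 gives > 30000 nM, again a limit. Compound 3 therefore stands only at a limit, and the same holds for every other value shown (the limit of > 30000 nM in this assay, at which 3 of the 3 values shown sit). Within the data shown here, the one single-point step, a step that the two limits leave unreadable from compound 2 to compound 3, is left unreadable by the two limits. Compound 4 differs from compound 3 by chloro in place of methoxy on an aromatic carbon. Among the measured compounds shown here, no measured step reads on this change, so no step beyond the scatter is expected, and the expected step is a step that the limit leaves unreadable from compound 3 to compound 4. Compound 4 is estimated at 50000 nM, within 20000 nM to 150000 nM.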

Compound 4, half-maximal inhibitory concentration: > 30000 nM
Compound 4 gave a limit, no number; the forecaster's own chance of this, stated with the estimate: 85%; the middle value is on the limit's open side.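

In this assay compound 4 gives > 30000 nM as a limit, and no new step can be read from compound 2 or compound 3 to compound 4. The size of any step in this assay stays open across compounds 1 to 4: the limit of > 30000 nM in this assay, at which 4 of the 4 values shown sit.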